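A few compounds are considered here, and "the series" means these few. Any claim that something is new, unique, unknown or untested is made for them only; others in the source may bear on it.

Compound 1 `COc1cc(OC)c2sc(-c3ccc(N/C=C\C(=O)c4ccc(OC)c(O)c4)c(C)c3)nc2c1` is the reference point here. Among the measured compounds shown here, in a functional assay on A549 cells (Homo sapiens) for antiproliferative activity, read by sulforhodamine B assay, with a stated time of 48 h (on this read-out higher numbers stand for weaker inhibition and lower numbers for stronger inhibition), compound 1 gives 14300 nM, the lowest of the two numbers so far, though not separated from its neighbour. Compound 2 `COc1ccc(C(=O)/C=C\Nc2ccc(-c3nc4cc(OC)c(OC)c(OC)c4s3)cc2C)cc1O` carries a methoxy in place of hydrogen on an aromatic carbon of the shared core, and in this assay compound 2 gives 15400 nM; the step of a 1.1-fold higher number from compound 1 to compound 2 (0.03 log units; within the scatter) is within the scatter. Compound 3 `COc1cc(OC)c2sc(-c3ccc(N/C=C\C(=O)c4ccc(OC)c(F)c4)c(C)c3)nc2c1` differs from compound 1 at the other end of the molecule: fluoro in place of hydroxy on an aromatic carbon. For the measured compounds named here, no measured step touches this aryl ketone portion, and the single step available concerns the core alone, so it does not bear on the change. With nothing to indicate a direction in this assay, no step beyond the scatter is expected, and the estimate for compound 3 is 15000 nM with a range of 5000 nM to 45000 nM, meaning an expected step of a 1.0-fold higher number from compound 1 to compound 3 (0.02 log units; within the scatter).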

Compound 3, half-maximal inhibitory concentration: 15300 nM
For compound 3 the middle estimate is 1.0-fold (0.01 log units) below the measured one; the measured number falls inside the stated range.
By their numbers in this assay, from the lowest: compounds 1, 3 and 2 (each within the scatter of the next).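

Fluoro in place of hydroxy on the 3-hydroxy-4-methoxyphenyl group gives a 1.1-fold higher number from compound 1 to compound 3 (0.03 log units; within the scatter), so in this assay this position, ortho to a methoxy group, shows no step beyond the scatter even though the hydrogen-bond donor and acceptor counted for hydroxy are gone. Among the compounds shown here, this is the first measured change at the aryl ketone end: the earlier step touched only the shared core, and now one change at each end has been read, neither beyond the scatter. No measured evidence bears on why the number holds here.

From the compounds shown here alone, whether another group at this position, such as an amine, a carboxylic acid or a longer alkoxy chain, would move the number beyond the scatter remains open. Also open, going by these compounds, is whether the fluoro and the added core methoxy would behave the same together on one compound.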